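The source may report more compounds than this note shows. Statements on the series, on what has been measured and on what is new or still open speak of the compounds shown alone.

Working notes on the uracil nucleotide series at an in vitro functional assay on 1321-N1 cells for agonist activity at P2Y purinoceptor 6 (Homo sapiens); on this read-out higher numbers stand for an effect only at larger amounts of compound and lower numbers for an effect already at smaller amounts.

Three compounds have numbers. Compound 1 `Cc1cc(=O)n([C@@H]2O[C@H](COP(=O)(O)OP(=O)(O)OP(=O)(O)O)[C@@H](O)[C@H]2O)c(=O)[nH]1` carries a triphosphate chain; in this assay compound 1 gives only the limit > 1000 nM, not a number. Compound 3 `Cc1cc(=O)n([C@@H]2O[C@H](COP(=O)(O)OP(=O)(O)O)[C@@H](O)[C@H]2O)c(=O)[nH]1` is its diphosphate; in this assay compound 3 likewise gives only the limit > 1000 nM. Among the compounds with values here, compound 2 `O=c1[nH]c(=O)n([C@@H]2O[C@H](COP(=O)(O)OP(=O)(O)O)[C@@H](O)[C@H]2O)cc1Br`, the diphosphate of the bromo-substituted core, gives 151 nM in this assay, the single real number in the set. The difference between the core of compound 1 and the core of compound 2 is not broken down here.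

The change from compound 1 to compound 3 is a hydrogen atom in place of a group of 4 heavy atoms (3 oxygen, 1 phosphorus; no ring), on an oxygen. Its step, a step that the two limits leave unreadable from compound 1 to compound 3, cannot be read, because both ends sit at the limit of > 1000 nM in this assay, at which 2 of the 3 values shown sit.

Compound 4 `O=c1[nH]c(=O)n([C@@H]2O[C@H](COP(=O)(O)O)[C@@H](O)[C@H]2O)cc1Br` is the monophosphate of the bromo core, and the change from compound 2 is the same one: a hydrogen atom in place of a group of 4 heavy atoms (3 oxygen, 1 phosphorus; no ring), on an oxygen. Within the data shown here, for compound 4 the step of a 20-fold higher number from compound 2 to compound 4 (1.30 log units; beyond the scatter) is expected to lose activity, an expectation that rests only on compound 2 giving 151 nM and on no measured step being readable. Compound 4 is estimated at 3000 nM, between 400 nM and 20000 nM.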

Compound 4, half-maximal effective concentration: > 1000 nM
Compound 4 ended at the assay's limit; the forecaster's own chance of this, stated with the estimate: 60%; the middle value lies beyond the limit too.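

In this assay, replacing the terminal phosphate group with hydrogen on the bromo core gives an at least 6.6-fold higher number from compound 2 to compound 4 (0.82 log units; beyond the scatter), so on this core the diphosphate has the lower number of the pair. Compound 4 gives > 1000 nM, which is a limit and not a number, so the step has a known minimum but no known size. This shows the change costing activity on one core only and does not show that the effect carries over to another core, because the same change from compound 1 to compound 3 cannot be read, with both compounds at the limit: the limit of > 1000 nM in this assay, at which 3 of the 4 values shown sit.

The compounds shown leave open how a triphosphate chain on the bromo core would read, and whether the step would recur on a second core whose diphosphate gives a real number. Also open, on these data alone, is how a carboxylic acid or an amine in place of the terminal phosphate group would read in this assay.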